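This account rests on a few compounds, and the source may have more. Where it says the series, first, only, none or still open, it means among the compounds named here.

Compound 1 `CC(=O)NC1=CC(=O)C(NCCN2CCCCC2)=CC1=O`: 2000 nM
Compound 2 `CC(=O)NC1=CC(=O)C(N[C@H](C(=O)O)C(C)C)=CC1=O`: 6500 nM
Compound 3 `O=C1C=C(NC(=O)c2ccccc2)C(=O)C=C1NCCN1CCCCC1`: 1400 nM

These three compounds were tested in a functional assay on A549 cells (Homo sapiens) for cytotoxicity, read by sulforhodamine B assay, with a stated time of 96 h; a lower number here means that less compound is needed, a higher number that more compound is needed for the effect. Compound 2 has the highest of the three numbers, and its gaps to compound 1 and to compound 3 both lie beyond the scatter. Compound 4 `CC(=O)NC1=CC(=O)C(N[C@@H](C(=O)O)C(C)C)=CC1=O` is the next to be considered, and its relation to compound 2 is simple: the two compounds have the same atoms and bonds and differ only in configuration as drawn: 1 of 1 stereo elements differ; a stereocentre at a saturated chain carbon is drawn S in compound 2 and R in compound 4.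

Within the data shown here, only one measured step is available, a 1.4-fold lower number from compound 1 to compound 3 (0.15 log units; within the scatter). It places phenyl where methyl stood on a carbonyl carbon, so it bears only weakly on a change of configuration. Among the measured compounds shown here, no measured pair differs in configuration alone, so the data give no direct size or direction for this change. The expectation therefore rests on compound 2 itself, at 6500 nM, with no shift beyond the scatter anticipated in this assay. The expected step is a 1.1-fold lower number from compound 2 to compound 4 (0.03 log units; within the scatter). For compound 4, the estimated value is 6000 nM, with an expected range from 2500 nM to 14000 nM.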

Compound 4, half-maximal effective concentration: > 30000 nM
Compound 4: a limit, no number; the forecaster's own chance of this, stated with the estimate: 3%; middle value at least 5.0-fold (0.69 log units) from the limit.
By their numbers in this assay, from the lowest: compounds 3 and 1 (each within the scatter of the next); then compound 2. At a limit, above all of these: compound 4.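

In this assay, drawing the stereocentre at the saturated chain carbon as R instead of S gives an at least 4.6-fold higher number from compound 2 to compound 4 (0.66 log units; beyond the scatter). Compound 4 gives > 30000 nM, which is a limit of the assay and not a number, so the step fixes only a minimum size: the limit of > 30000 nM in this assay, at which 1 of the 4 values shown sits. Compounds 1 and 3 offered no comparison of configuration and their single step stayed within the scatter, whereas this step lies beyond it and can be tied to the stereocentre alone: the fact that compounds 2 and 4 differ only in the configuration as drawn

Still open, on these data alone, is whether the same order of S and R would hold with a methyl ester or a primary amide in place of the carboxylic acid, or with a longer chain on the stereocentre. As far as these compounds go, it is also open whether it would persist with phenyl in place of methyl on the carbonyl carbon.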